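The compounds below may be only part of what the source reports. "The series", "measured", "known", "first", "only" and "open" are said of these compounds alone.

Compound 1 `O=C(O)c1ccccc1-c1ccc(CCc2ncc(CC3CC3)[nH]2)cc1` gives 72 nM in an in vitro functional assay on cells for agonist activity at Bombesin receptor subtype-3 (Mus musculus), read by luminescence and calcium flux (a lower number here means that less compound is needed, a higher number that more compound is needed for the effect), and compound 2 `O=C(O)c1ccccc1-c1ccc(CCc2ncc(Cc3ccccc3)[nH]2)cc1` gives 11 nM. Of the two numbers shown, compound 2 stands lowest; its nearest neighbour is compound 1, and the step between them, a 6.5-fold lower number from compound 1 to compound 2 (0.82 log units; beyond the scatter), is the only measured step in this series. Compound 3 `O=C(O)c1ccccc1-c1ccc(CCc2ncc(CC3CCCCCC3)[nH]2)cc1` differs from compound 2 by cycloheptyl in place of phenyl on a saturated chain carbon bound to an aromatic carbon. For the measured compounds named here, the one measured step bears on this change only in part: it shows what exchanging a non-aromatic ring for phenyl did, and the present change runs the other way, back to a non-aromatic ring, though a larger one than before. On that basis compound 3 is expected to give a somewhat higher number than compound 2, a step of a 3.6-fold higher number from compound 2 to compound 3 (0.56 log units; beyond the scatter), estimated at 40 nM with a likely range from 12 nM to 130 nM.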

Compound 3, half-maximal effective concentration: 5.7 nM
Compound 3: middle estimate off by 7.0-fold (0.85 log units), on the high side, outside the stated range (below it).
By their numbers in this assay, from the lowest: compounds 3 and 2 (each within the scatter of the next); then compound 1.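

In this assay, the step of a 1.9-fold lower number from compound 2 to compound 3 (0.29 log units; within the scatter) lies within the usual scatter, so on a saturated chain carbon bound to an aromatic carbon, cycloheptyl and phenyl cannot be told apart, and an aromatic ring is not needed for a number of this size. The step of a 13-fold lower number from compound 1 to compound 3 (1.10 log units; beyond the scatter) lies beyond the scatter, so the earlier gap between cyclopropyl and phenyl does not simply separate non-aromatic rings from aromatic ones, since the two non-aromatic rings themselves stand apart. No measurement at hand accounts for this result.

The compounds shown leave open whether a ring of intermediate size, such as cyclohexyl, would follow cycloheptyl or cyclopropyl. They also leave open whether a ring is needed here at all, which an open hexyl chain would test, and how an amine on the ring would fare.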